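Methylating the cyclohexanol: compound 3 to compound 4

The source may hold more compounds than are shown below. What is called first, only, known or untested is meant among the compounds shown, and "the series" means these compounds.

Going by the values given here, compound 3 `N#Cc1cnc(NCc2cnccc2C(F)(F)F)cc1N[C@H]1CC[C@@H](O)CC1` carries the only number in the set from an assay on isolated protein for inhibition of protein kinase C delta type (Homo sapiens), read by TR-FRET, with a stated time of 2 h; a higher number here means a weaker inhibitor, a lower number a stronger inhibitor; in it compound 3 gives 4500 nM. Compound 1 `N#Cc1cnc(NCc2cnccc2C(F)(F)F)cc1N[C@H]1C[C@H](O)C1` reaches only the limit of this assay, > 10000 nM. Compound 2 `N#Cc1cnc(NCc2cnccc2C(F)(F)F)cc1NC[C@H]1C[C@H](O)C1` likewise sits at the limit, > 10000 nM. The steps of an at least 2.2-fold lower number from compound 1 to compound 3 (0.34 log units; beyond the scatter) and an at least 2.2-fold lower number from compound 2 to compound 3 (0.34 log units; beyond the scatter) are therefore lower bounds only (the limit of > 10000 nM in this assay, at which 2 of the 3 values shown sit). Compound 4 `CO[C@H]1CC[C@@H](Nc2cc(NCc3cnccc3C(F)(F)F)ncc2C#N)CC1` differs from compound 3 by methyl in place of hydrogen on an oxygen on a saturated carbon. Among the compounds with values here, none of the measured steps touches the oxygen of the 4-hydroxycyclohexyl group; they change the ring carried on the nitrogen, so no measured step bears directly on this change. The step from compound 3 to compound 4 in this assay is expected to be a 1.1-fold higher number from compound 3 to compound 4 (0.05 log units; within the scatter), within the scatter. Compound 4 is thus estimated at 5000 nM, between 1500 nM and 15000 nM.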

Compound 4, half-maximal inhibitory concentration: 5000 nM
For compound 4 middle estimate and measured number coincide at the digits printed; low and high end bracket the measured number.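

In this assay, the oxygen of the 4-hydroxycyclohexyl group takes methyl in place of hydrogen with a 1.1-fold higher number from compound 3 to compound 4 (0.05 log units; within the scatter), so hydroxy and methoxy stand level at this position. The comparisons with the smaller rings yield only floors, an at least 2.0-fold lower number from compound 2 to compound 4 (0.30 log units; that floor lies within the scatter) and an at least 2.0-fold lower number from compound 1 to compound 4 (0.30 log units; that floor lies within the scatter), and these remain bounds: the limit of > 10000 nM in this assay, at which 2 of the 4 values shown sit.

The compounds shown leave open whether a longer ether such as ethoxy or benzyloxy, or an amine or a carboxylic acid at this place, would hold the number at this level. Also open, going by these compounds, is what methoxy would do on the 3-hydroxycyclobutyl group.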